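This account rests on a few compounds, and the source may have more. Where it says the series, first, only, none or still open, it means among the compounds named here.

Measured in a functional assay on PC-3 cells (Homo sapiens) for cytotoxicity, read by MTT assay, with a stated time of 72 h; a lower number here means a stronger inhibitor, a higher number a weaker inhibitor:
- compound 1 `N#Cc1ccc(/C=N/NC(=O)Nc2cc3c(Nc4ccc(F)c(Cl)c4)ncnc3cc2O[C@H]2CCOC2)cc1`: 28100 nM
- compound 2 `COc1cc2ncnc(Nc3ccc(F)c(Cl)c3)c2cc1NC(=O)N/N=C/c1cccc(Br)c1`: "not active" (no number reported)

Compound 2 has no single number: its only record is "not active" (no number reported). The next step leads to compound 3 `COc1cc2ncnc(Nc3ccc(F)c(Cl)c3)c2cc1NC(=O)N/N=C/c1ccc(C#N)cc1`, with 4-cyanophenyl in place of 3-bromophenyl on a carbon with a double bond to nitrogen. Compound 1, which also carries 4-cyanophenyl, gives 28100 nM, so only weak inhibition is in view. In this assay a small step toward stronger inhibition is expected, ending in the weak range or again without a number. For compound 3 the estimated value is 25000 nM, with an expected range of 9000 nM to 70000 nM.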

Compound 3, half-maximal inhibitory concentration: 36500 nM
Compound 3: the middle estimate sits 1.5-fold (0.16 log units) below what was measured; low and high end bracket the measured number.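

In this assay, the step of a 1.3-fold higher number from compound 1 to compound 3 (0.11 log units; within the scatter) shows that methyl in place of oxolan-3-yl on an oxygen on an aromatic ring leaves the reading within the scatter when 4-cyanophenyl is present. With 4-cyanophenyl in place of 3-bromophenyl, compound 3 gives a number where compound 2 has only "not active", but that step cannot be read as a size.

On these data alone, whether a longer chain in place of methyl, or an amine in place of the nitrile, would shift the reading stays open. No measurement on hand accounts for these results.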